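Fluorine placement on the benzyl group and cytotoxicity

The source may hold more compounds than are shown below. What is called first, only, known or untested is meant among the compounds shown, and "the series" means these compounds.

Measured compounds:
compound 1 `CCOC(=O)/C(O)=C/C(=O)c1cn(Cc2ccc(F)c(F)c2)c2cccc(OC)c12` — 125000 nM
compound 2 `COc1cccc2c1c(C(=O)/C=C(\O)C(=O)O)cn2Cc1c(F)cccc1F` — 44300 nM
compound 3 `COc1cccc2c1c(C(=O)/C=C(\O)C(=O)O)cn2Cc1cc(F)cc(F)c1` — 29500 nM

In an ADME assay on MT4 cells (Homo sapiens) for cytotoxicity, read by MTT assay (on this read-out higher numbers stand for lower toxicity in this test and lower numbers for higher toxicity in this test), compound 1 gives 125000 nM, the highest of the three numbers. Compound 2 gives 44300 nM and compound 3 gives 29500 nM; both of these gaps to compound 1 lie beyond the scatter, but compound 2 and compound 3 also differ from compound 1 in the ester part of the shared core, so they do not isolate the benzyl change.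

Compound 4 `CCOC(=O)/C(O)=C/C(=O)c1cn(Cc2ccc(F)cc2F)c2cccc(OC)c12` is not yet measured. It differs from compound 1 only in the benzyl part: 2,4-difluorophenyl in place of 3,4-difluorophenyl on a saturated chain carbon bound to an aromatic nitrogen

Among the compounds with values here, the one measured step that bears on this kind of change is the step of a 1.5-fold lower number from compound 2 to compound 3 (0.18 log units; within the scatter). That move between two fluorine patterns did not shift the result beyond the scatter, so no step beyond the scatter is expected from compound 1 to compound 4 either; the expected step is a 1.1-fold lower number from compound 1 to compound 4 (0.06 log units; within the scatter).

Compound 4 is therefore estimated at 110000 nM, with a range from 50000 nM to 250000 nM.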

Compound 4, half-maximal cytotoxic concentration: 65500 nM
Beside the measured number, compound 4's estimate is 1.7-fold (0.23 log units) above it; low and high end bracket the measured number.
By their numbers in this assay, from the lowest: compounds 3, 2, 4 and 1 (each within the scatter of the next, the first and the last beyond it).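

In this assay, the ester form of the shared core now has a one-place reading at this position: a 1.9-fold lower number from compound 1 to compound 4 (0.28 log units; within the scatter). Together with the earlier step on compounds 2 and 3, this makes two changes of fluorine pattern on the benzyl group, one in each form of the core, and neither lies beyond the scatter. No measurement shown here explains the step from 3,4-difluorobenzyl to 2,4-difluorobenzyl.

No pair shown shares a fluorine pattern across the ester and the carboxylic acid, so the ester part remains unseparated from the benzyl change. Also open, as far as these compounds go, is whether an unsubstituted benzyl, a chlorobenzyl or a longer chain at this place would move the number beyond the scatter.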